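A few compounds are considered here, and "the series" means these few. Any claim that something is new, unique, unknown or untested is made for them only; others in the source may bear on it.

Of the compounds shown here, three with a shared core have been measured in a functional assay on A-375 cells (Homo sapiens) for cytotoxicity, read by MTT assay, with a stated time of 72 h; on this read-out lower numbers stand for stronger inhibition and higher numbers for weaker inhibition. Compound 1 `O=C1c2c[n+]([O-])c3ccccc3c2C(=O)c2c1c1ccccc1n2CCCCn1ccnc1` gives 350 nM. Compound 2 `O=C1c2c[n+]([O-])c3ccccc3c2C(=O)c2c1c1ccccc1n2Cc1cn(C[C@H](O)CO)nn1` gives 350 nM. Compound 3 `CN1CCN(CCCn2c3c(c4ccccc42)C(=O)c2c[n+]([O-])c4ccccc4c2C3=O)CC1` gives 470 nM, which lies within the usual scatter of both other values, so no order can be drawn among the three.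

Compound 4 `CN(C)CCCCn1c2c(c3ccccc31)C(=O)c1c[n+]([O-])c3ccccc3c1C2=O` has not yet been measured. It differs from compound 3 in one place, on a saturated chain carbon, three bonds along the chain from an aromatic nitrogen: (dimethylamino)methyl in place of 4-methylpiperazin-1-yl on a saturated chain carbon, three bonds along the chain from an aromatic nitrogen. In other words, (dimethylamino)methyl stands in place of 4-methylpiperazin-1-yl, and the side chain becomes 4-(dimethylamino)butyl.

The most relevant measured step is the one made at that same place, a 1.3-fold higher number from compound 1 to compound 3 (0.13 log units; within the scatter). Two swaps of the side chain further out point the same way: no change at the digits printed from compound 1 to compound 2 (within the scatter), and a 1.3-fold higher number from compound 2 to compound 3 (0.13 log units; within the scatter). Across these three compounds, then, quite different side chains have left the number unmoved, and none of the three goes against this. Three compounds are a thin basis, and none of them carries an open-chain dimethylamino group. No step beyond the scatter is therefore expected, and the estimated step is a 1.2-fold lower number from compound 3 to compound 4 (0.07 log units; within the scatter). For compound 4 the expected value is 400 nM, with an estimated range from 170 nM to 900 nM.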

Compound 4, half-maximal inhibitory concentration: 470 nM
Compound 4: the middle estimate sits 1.2-fold (0.07 log units) below what was measured; the measured number falls inside the stated range.
By their numbers in this assay, from the lowest: compounds 1, 2, 3 and 4 (each within the scatter of the next).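

In this assay, putting (dimethylamino)methyl in place of 4-methylpiperazin-1-yl, on a saturated chain carbon three bonds along the chain from an aromatic nitrogen, gives no change at the digits printed from compound 3 to compound 4 (within the scatter) and so removes the six-membered ring without any step beyond the scatter. Going by these compounds alone, the resulting 4-(dimethylamino)butyl chain, an open-chain amine not seen in the earlier compounds, also stays close to the other two side chains, with a 1.3-fold higher number from compound 1 to compound 4 (0.13 log units; within the scatter) and a 1.3-fold higher number from compound 2 to compound 4 (0.13 log units; within the scatter) in the same read-out; all four side chains now fall within the scatter of one another, ring or no ring. Nothing available here explains why these side chains read alike.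

The compounds shown do not reveal whether any group on this chain can move the number beyond the scatter, leaving open what a terminal carboxylic acid, a plain hexyl chain without nitrogen or a shorter 2-(dimethylamino)ethyl chain would give. They also leave open whether the same flat picture would hold outside this assay or with changes made to the shared core rather than to the side chain.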